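A few compounds are considered here, and "the series" means these few. Any claim that something is new, unique, unknown or untested is made for them only; others in the source may bear on it.

Compound 1 `CCN(CC)CCCOc1cc2ncnc(Nc3nc4ccc(C(=O)Nc5c(C)cc(C)cc5C)cc4s3)c2cc1OC` and compound 2 `COc1cc2c(Nc3nc4ccc(C(=O)Nc5c(C)cc(C)cc5C)cc4s3)ncnc2cc1OCCCN1CCCCC1` share one core and differ only in the amine at the end of a chain. In a functional assay on A549 cells (Homo sapiens) for cytotoxicity, read by WST assay, with a stated time of 72 h (a higher number here means a weaker inhibitor, a lower number a stronger inhibitor), compound 1 gives 5700 nM and compound 2 gives 10300 nM. Compound 2 has the highest of the two numbers, with compound 1 the nearest; the step of a 1.8-fold higher number from compound 1 to compound 2 (0.26 log units; within the scatter) shows the two are not separated beyond the scatter. Compound 3 `COc1cc2c(Nc3nc4ccc(C(=O)Nc5c(C)cc(C)cc5C)cc4s3)ncnc2cc1OCCCN1CCCC1` carries the change (pyrrolidin-1-yl in place of piperidin-1-yl on a saturated chain carbon, three bonds along the chain from an oxygen on an aromatic ring). For the measured compounds named here, the only step that bears on this change is the earlier swap of one amine for another at the same place, and it produced nothing beyond the scatter. A further swap of one saturated ring amine for a smaller one is therefore expected to give a step of a 1.3-fold lower number from compound 2 to compound 3 (0.11 log units; within the scatter) in this assay, that is, no change beyond the scatter. Compound 3 is estimated at 8000 nM, within a range from 3500 nM to 20000 nM.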

Compound 3, half-maximal inhibitory concentration: 8900 nM
The estimate for compound 3 lay 1.1-fold (0.05 log units) below the measured number; measured number inside the range.
By their numbers in this assay, from the lowest: compounds 1, 3 and 2 (each within the scatter of the next).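

In this assay, the ring change gives a 1.2-fold lower number from compound 2 to compound 3 (0.06 log units; within the scatter) and the swap from the open diethylamino group to the ring gives a 1.6-fold higher number from compound 1 to compound 3 (0.19 log units; within the scatter) on the same chain. With the earlier step, all three amines now sit within the scatter of one another, so at this place on the chain neither the size of the saturated ring nor the difference between an open and a ring amine separates these compounds in this cell assay. No measurement shown offers an explanation for this lack of separation.

Still open, as far as these compounds go, is whether a ring amine with a second hetero atom, such as morpholin-4-yl or 4-methylpiperazin-1-yl, would move the number beyond the scatter. The same question applies to a longer chain carrying one of these amines.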